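This account rests on a few compounds, and the source may have more. Where it says the series, first, only, none or still open, it means among the compounds named here.

Compound 3 `CCN(CC)CCNC(=O)c1ccc(C(CC)(CC)c2ccc(OCC(O)C(C)(C)C)c(C)c2)n1CC` gives 110 nM in an assay on HL-60 cells for agonist activity at vitamin D3 receptor (Homo sapiens), read by microscopy, with a stated time of 96 h; a higher number here means that more compound is needed for the effect, a lower number that less compound is needed. Among the three compounds measured it holds the second highest number: compound 1 `CCN(CC)CCNC(=O)c1ccc(C(CC)(CC)c2ccc(OCC(=O)C(C)(C)C)c(C)c2)n1CC` gives 91 nM, and the two lie within the scatter of each other (a 1.2-fold higher number from compound 1 to compound 3 (0.08 log units; within the scatter)), while compound 2 `C=CCN(C)C(=O)c1ccc(C(CC)(CC)c2ccc(OCC(=O)C(C)(C)C)c(C)c2)n1CC` gives 21600 nM, far above both. Compound 4 `C#CCCOC(=O)c1ccc(C(CC)(CC)c2ccc(OCC(O)C(C)(C)C)c(C)c2)n1CC` has not yet been measured. It differs from compound 3 on the carbonyl carbon whose other neighbour is an aromatic carbon: (but-3-yn-1-yl)oxy in place of (2-(diethylamino)ethyl)amino on a carbonyl carbon. Within the data shown here, one measured step bears on this change. Because a 240-fold higher number from compound 1 to compound 2 (2.38 log units; beyond the scatter) removed the same (2-(diethylamino)ethyl)amino group from that carbonyl carbon and the number rose sharply, a large upward step is expected here too, since compound 4 loses the same group and gains a (but-3-yn-1-yl)oxy group with no hydrogen-bond donor. The expected step is a 140-fold higher number from compound 3 to compound 4 (2.13 log units; beyond the scatter). Compound 4 is therefore estimated to give about 15000 nM in this assay, with a likely range from 3000 nM to 60000 nM.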

Compound 4, half-maximal effective concentration: 1030 nM
Compound 4: the middle estimate sits 15-fold (1.16 log units) above what was measured; the measured number lies below the stated range.
By their numbers in this assay, from the lowest: compounds 1 and 3 (each within the scatter of the next); then compound 4; then compound 2.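

In this assay, the step of a 9.4-fold higher number from compound 3 to compound 4 (0.97 log units; beyond the scatter) shows that the number rises beyond the scatter when (but-3-yn-1-yl)oxy replaces (2-(diethylamino)ethyl)amino on this carbonyl carbon, yet the step is only modest. Losing that group therefore does not always bring a step as large as a 240-fold higher number from compound 1 to compound 2 (2.38 log units; beyond the scatter) and the large step seen with allyl(methyl)amino does not carry over in full to this change, although these two steps differ both in the entering group and in the 1-hydroxy-2,2-dimethylpropyl or (tert-butyl)carbonyl group at the other end. No measurement shown here accounts for the difference in size between the two steps.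

The compounds shown cannot separate the contribution of the entering group from that of the other end. They also leave open how a carboxylic acid, or a shorter amine such as (2-aminoethyl)amino, would behave on this carbonyl carbon.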